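Hydroxy to methoxy step in two related cores

The source may hold more compounds than are shown below. What is called first, only, known or untested is meant among the compounds shown, and "the series" means these compounds.

Measured compounds:
compound 1 `COc1cc(C[C@H]2C(=O)OC[C@@H]2Cc2ccccc2)ccc1O`: 93000 nM
compound 2 `COc1ccc(C[C@H]2C(=O)OC[C@@H]2Cc2ccccc2)cc1OC`: > 100000 nM, a limit of the assay rather than a number
compound 3 `COc1ccc(C[C@H]2COC[C@@H]2Cc2ccc(Cl)c(Cl)c2)cc1O`: 33000 nM

All values come from a functional assay on HL-60 cells (Homo sapiens) for cytotoxicity, read by WST assay, with a stated time of 48 h; on this read-out higher numbers stand for an effect only at larger amounts of compound and lower numbers for an effect already at smaller amounts. Compound 1 and compound 2 differ by methyl in place of hydrogen on an oxygen on an aromatic ring, and the step is an at least 1.0-fold higher number from compound 1 to compound 2 (0.03 log units; that floor lies within the scatter). Its size is only a floor because of the limit of > 100000 nM in this assay, at which 1 of the 3 values shown sits. Compound 3 stands lowest of the two numbers, with compound 1 nearest; how the core of compound 3 differs from the core of compound 1 is not broken down here.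

Compound 4 `COc1ccc(C[C@H]2COC[C@@H]2Cc2ccc(Cl)c(Cl)c2)cc1OC` is not yet measured in this assay. It differs from compound 3 by methyl in place of hydrogen on an oxygen on an aromatic ring, the same change as from compound 1 to compound 2. For compound 4 the expected step is a 1.5-fold higher number from compound 3 to compound 4 (0.18 log units; within the scatter), resting on the earlier step of an at least 1.0-fold higher number from compound 1 to compound 2 (0.03 log units; that floor lies within the scatter), which is known only as a floor; a similar or somewhat higher number is expected. The estimate for compound 4 in this assay is 50000 nM, between 20000 nM and 120000 nM.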

Compound 4, half-maximal effective concentration: 16000 nM
Beside the measured number, compound 4's estimate is 3.1-fold (0.49 log units) above it; the whole stated range lies above it.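

Hydroxy to methoxy on the core of compound 3 gives a 2.1-fold lower number from compound 3 to compound 4 (0.31 log units; beyond the scatter) in this assay, so on this core the methyl in place of hydrogen goes with a modest move to a lower number. This does not show that the change carries over from one core to another with the same size or direction, nor that it behaves differently on the two cores: the same change on two cores in this assay, an at least 1.0-fold higher number (0.03 log units; that floor lies within the scatter) from compound 1 to compound 2 and a 2.1-fold lower number (0.31 log units; beyond the scatter) from compound 3 to compound 4; the limit leaves it open whether they differ. The reading on the core of compound 1 remains bounded on one side only, so the comparison rests on a single measured step and a floor: the limit of > 100000 nM in this assay, at which 1 of the 4 values shown sits.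

The compounds shown leave open whether a longer chain on the same oxygen, such as ethyl in place of methyl, would continue the step seen from the hydroxy compound to the methoxy compound on the core of compound 3. Also open, going by these compounds, is how an amine in place of the hydroxy group would read on either core.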